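This account rests on a few compounds, and the source may have more. Where it says the series, first, only, none or still open, it means among the compounds named here.

Of the compounds shown here, two have so far been measured in an assay for inhibition of MAP kinase-interacting serine/threonine-protein kinase 2 (Homo sapiens), read by TR-FRET; on this read-out lower numbers stand for stronger inhibition and higher numbers for weaker inhibition. Compound 1 `CCn1cc(-c2ccnc(Nc3ccc(OC)cc3OC)n2)c2ccccc21` gives 430 nM in this assay, while compound 2 `COc1ccc(Nc2nccc(-c3c[nH]c4ccccc34)n2)c(OC)c1` gives 110 nM. Among the compounds with values here, compound 2 thus stands at the lower of the two numbers, and the single measured step between them, a 3.9-fold lower number from compound 1 to compound 2 (0.59 log units; beyond the scatter), came with hydrogen in place of ethyl on an aromatic nitrogen.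

Compound 3 `COc1ccc(Nc2nccc(-c3cn(C)c4ccccc34)n2)c(OC)c1` has not been measured. It differs from compound 2 by methyl in place of hydrogen on an aromatic nitrogen. Within the data shown here, the one step that bears on this change is a 3.9-fold lower number from compound 1 to compound 2 (0.59 log units; beyond the scatter), in which the group on that same aromatic nitrogen was taken away; putting a methyl there partly reverses that step. A rise in the number is therefore expected, of a size probably somewhat below the earlier step. For compound 3 the estimate in this assay is 250 nM, with a range from 110 nM to 560 nM. The expected step is a 2.3-fold higher number from compound 2 to compound 3 (0.36 log units; beyond the scatter).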

Compound 3, inhibition constant: 610 nM
Beside the measured number, compound 3's estimate is 2.4-fold (0.39 log units) below it; the measured number lies above the stated range.
By their numbers in this assay, from the lowest: compound 2; then compounds 1 and 3 (each within the scatter of the next).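

In this assay, a 5.5-fold higher number from compound 2 to compound 3 (0.74 log units; beyond the scatter) shows that a methyl on this aromatic nitrogen, a single carbon, is already enough to give a number as high as the ethyl did, so the benefit of hydrogen there does not depend on a group as large as ethyl. The comparison of the two alkyl groups, a 1.4-fold higher number from compound 1 to compound 3 (0.15 log units; within the scatter), lies within the scatter, so among these three compounds the clear difference at this position is between hydrogen and either carbon group, with methyl and ethyl not told apart. Nothing available explains this difference.

From the compounds shown here alone, whether a longer chain such as butyl, or a chain ending in an amine or a carboxylic acid, would give a similar number at this nitrogen remains open. The compounds shown also leave open whether the same difference between hydrogen and methyl would hold with another group elsewhere on the shared core.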